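Sulfonyl linker variation in the chlorobutyl-urea series

This account rests on a few compounds, and the source may have more. Where it says the series, first, only, none or still open, it means among the compounds named here.

Among the compounds with values here, compound 2 `O=C(NCCCCl)Nc1cccc(S(=O)(=O)Oc2ccc(O)cc2)c1` gives 51000 nM in a functional assay on HT-29 cells (Homo sapiens) for cytotoxicity, read by sulforhodamine B assay, with a stated time of 48 h (on this read-out higher numbers stand for weaker inhibition and lower numbers for stronger inhibition), the highest of the two numbers measured so far; its nearest neighbour, compound 1 `Cc1ccccc1OS(=O)(=O)c1cccc(NC(=O)NCCCCl)c1`, gives 21000 nM, with a 2.4-fold higher number from compound 1 to compound 2 (0.39 log units; beyond the scatter). Compound 3 `Cc1ccccc1NS(=O)(=O)c1cccc(NC(=O)NCCCCl)c1` differs from compound 2 thus: (2-methylphenyl)amino in place of 4-hydroxyphenoxy on a sulfonyl sulfur. Within the data shown here, the single measured step bears on it, where 4-hydroxyphenyl in place of 2-methylphenyl on an oxygen raised the number modestly. Compound 3 restores the 2-methylphenyl ring, now as (2-methylphenyl)amino on the sulfonyl sulfur. For compound 3 the expected step is a 2.6-fold lower number from compound 2 to compound 3 (0.41 log units; beyond the scatter), back toward the number of compound 1. Compound 3 is estimated at 20000 nM, range 7000 nM to 60000 nM.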

Compound 3, half-maximal inhibitory concentration: 42000 nM
The estimate for compound 3 lay 2.1-fold (0.32 log units) below the measured number; the measured number falls inside the stated range.
By their numbers in this assay, from the lowest: compounds 1, 3 and 2 (each within the scatter of the next, the first and the last beyond it).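

In this assay, with the ring kept, the linking atom on the sulfonyl sulfur can be nitrogen or oxygen without a resolved difference: a 2.0-fold higher number from compound 1 to compound 3 (0.30 log units; within the scatter) lies within the scatter. Against the 4-hydroxyphenoxy group, a 1.2-fold lower number from compound 2 to compound 3 (0.08 log units; within the scatter) is also within the scatter, so compound 3 cannot be separated from either neighbour, although compound 1 and compound 2 are separated. Nothing available accounts for this result.

Still open, on these data alone, is whether a carboxylic acid or an amine on this ring would give a number beyond the scatter of these three. The same holds for a longer chain on the urea.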